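This account rests on a few compounds, and the source may have more. Where it says the series, first, only, none or still open, it means among the compounds named here.

Working notes on the series sharing the core of compound 1 `CCCn1c(=O)n(C)c(=O)c2c1ncn2CC(N)=O`, all with the chain on the aromatic nitrogen varied in one place. In an assay on Cerebral cortex for binding affinity to adenosine receptor A1 (Cavia porcellus), read by radioligand binding (on this read-out lower numbers stand for stronger inhibition and higher numbers for weaker inhibition), compound 1 gives only a limit, > 200000 nM. Compound 2 `CCCn1c(=O)n(C)c(=O)c2c1ncn2CC#N` gives 6600 nM in this assay, and compound 3 `CCCn1c(=O)n(C)c(=O)c2c1ncn2CCO` gives 41400 nM. Among the two numbers shown, compound 3 stands highest, with compound 2 nearest at a 6.3-fold higher number from compound 2 to compound 3 (0.80 log units; beyond the scatter); the remaining value is the limit of compound 1 (the limit of > 200000 nM in this assay, at which 1 of the 3 values shown sits). The steps at this chain have been clear: an at least 30-fold lower number from compound 1 to compound 2 (1.48 log units; beyond the scatter) and an at least 4.8-fold lower number from compound 1 to compound 3 (0.68 log units; beyond the scatter).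

Compound 4 `CCCn1c(=O)n(C)c(=O)c2c1ncn2CCOCC` differs from compound 3 by ethyl in place of hydrogen on an oxygen on a saturated carbon, the hydroxy becoming ethoxy, the 2-hydroxyethyl a 2-ethoxyethyl. Among the measured compounds shown here, the steps that bear on it, cyano for carbamoyl and hydroxymethyl for carbamoyl and for cyano, all changed the terminal group on the same chain carbon and each moved the number beyond the scatter, from modest to large. The change to compound 4 is a smaller one, an ethyl added at the oxygen rather than a new terminal group, so a modest step is expected, with the direction most likely toward a lower number, as both terminal groups without the amide did better than the carbamoyl of compound 1. The step from compound 3 to compound 4 in this assay is expected to be about a 2.8-fold lower number from compound 3 to compound 4 (0.44 log units; beyond the scatter). For compound 4 the expected value in this assay is 15000 nM, within a range from 4000 nM to 60000 nM.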

Compound 4, inhibition constant: 24300 nM
The estimate for compound 4 lay 1.6-fold (0.21 log units) below the measured number; the range from low to high includes it.
By their numbers in this assay, from the lowest: compound 2; then compounds 4 and 3 (each within the scatter of the next). At a limit, above all of these: compound 1.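

In this assay, among the compounds shown here, the step of a 1.7-fold lower number from compound 3 to compound 4 (0.23 log units; within the scatter) is the first at this chain to stay within the scatter, so ethyl in place of hydrogen on this oxygen gives no readable separation between the 2-hydroxyethyl and the 2-ethoxyethyl. The step of a 3.7-fold higher number from compound 2 to compound 4 (0.57 log units; beyond the scatter) joins a 6.3-fold higher number from compound 2 to compound 3 (0.80 log units; beyond the scatter) as a step beyond the scatter, which leaves the nitrile of compound 2 with the lowest number among the terminal groups shown on this chain. Compound 1 gives only a limit, so the step of an at least 8.2-fold lower number from compound 1 to compound 4 (0.91 log units; beyond the scatter) is a bound and not a measured size: the limit of > 200000 nM in this assay, at which 1 of the 4 values shown sits.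

From the compounds shown here alone, it remains open whether an amine or a carboxylic acid at the end of the same chain would come close to compound 2, and whether a longer chain ending in the nitrile would keep its number. Going by these compounds, it is also open whether a methyl or a benzyl on the oxygen would stay within the scatter of compound 3 as the ethyl of compound 4 does.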